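This account rests on a few compounds, and the source may have more. Where it says the series, first, only, none or still open, it means among the compounds named here.

Measured so far in an ADME assay on Vero cells (Chlorocebus sabaeus) for cytotoxicity, with a stated time of 72 h; a higher number here means a weaker inhibitor, a lower number a stronger inhibitor:

Compound 1 `CCOC(=O)c1cc(-c2cccc(OCc3ccccc3)c2)on1` — > 128000 nM, a limit of the assay.
Compound 2 `CCOC(=O)c1cc(-c2cccc(OCc3ccccc3[N+](=O)[O-])c2)on1` — > 128000 nM, a limit of the assay.
Compound 3 `CCOC(=O)c1cc(-c2cccc(OCc3cccc(F)c3F)c2)on1` — > 128000 nM, a limit of the assay.

Compound 3 therefore stands at the limit in this assay, and it stands there together with both other compounds, all three sitting at the limit of > 128000 nM in this assay, at which 3 of the 3 values shown sit. None of the steps between the measured compounds can be read: the step that the two limits leave unreadable from compound 1 to compound 2, the step that the two limits leave unreadable from compound 1 to compound 3 and the step that the two limits leave unreadable from compound 2 to compound 3 are each hidden by the two limits that bound them.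

Compound 4 `CCOC(=O)c1cc(-c2cccc(OCc3ccc(F)c(F)c3F)c2)on1` differs from compound 3 by fluoro in place of hydrogen on an aromatic carbon. Among the compounds with values here, no measured step in this assay concerns a change of this kind, and the three steps that exist give no readable size in either direction; what they do show is that exchanges among the benzyl groups of this series have not moved any value off the limit.

On that basis compound 4 is expected to remain at the limit as well, the step that the limit leaves unreadable from compound 3 to compound 4 being expected to show no readable change beyond the scatter. The estimate for compound 4 in this assay is 150000 nM, within a range of 90000 nM to 300000 nM.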

Compound 4, half-maximal inhibitory concentration: > 128000 nM
Compound 4: no number, only a limit (the forecaster's own chance of this, stated with the estimate: 85%); the middle value is on the limit's open side.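

In this assay compound 4 gives > 128000 nM as a limit of the assay. The steps joining compound 4 to compound 1, compound 2 and compound 3 cannot be read, and all four compounds share one limit: the limit of > 128000 nM in this assay, at which 4 of the 4 values shown sit. The compounds shown leave open whether these benzyl groups differ at all in cytotoxicity on these cells.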